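Demethylating the Sulfamide: From Compound 3 to Compound 4

A few compounds are considered here, and "the series" means these few. Any claim that something is new, unique, unknown or untested is made for them only; others in the source may bear on it.

Compounds measured so far in a functional assay on the whole organism for inhibition, with Mus musculus as the target; on this read-out lower numbers stand for an effect already at smaller amounts and higher numbers for an effect only at larger amounts of compound:
compound 1, `CCN1CCCC1CNC(=O)c1cc(NS(=O)(=O)N(C)C)c(Cl)cc1OC`, gives 8.3 mg/kg;
compound 2, `CCN1CCCC1CNC(=O)c1cc(N(C)S(=O)(=O)N(C)C)c(C)cc1OC`, gives only a limit, > 50 mg/kg;
compound 3, `CCN1CCCC1CNC(=O)c1cc(N(C)S(=O)(=O)N(C)C)c(Cl)cc1OC`, gives 31.8 mg/kg.

Compound 3 stands at the highest of the two numbers in this assay; compound 1 is its nearest neighbour, and the step of a 3.8-fold higher number from compound 1 to compound 3 (0.58 log units; beyond the scatter) is the one that separates them. The limit of compound 2 sits at the limit of > 50 mg/kg in this assay, at which 1 of the 3 values shown sits, and the step of an at least 1.5-fold lower number from compound 2 to compound 3 (0.19 log units; that floor lies within the scatter) can only be bounded from one side.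

Compound 4, `CCN1CCCC1CNC(=O)c1cc(NS(=O)(=O)NC)c(Cl)cc1OC`, differs from compound 3 in one place: (methylsulfamoyl)amino in place of (dimethylsulfamoyl)(methyl)amino on an aromatic carbon. For the measured compounds named here, the change takes a methyl away from the nitrogen on the aromatic ring, which is the reverse of the step of a 3.8-fold higher number from compound 1 to compound 3 (0.58 log units; beyond the scatter), and at the same time takes a methyl away from the far nitrogen of the sulfamoyl group, a change for which no measured step exists. Only the first part can be weighed, and it points toward a lower number in this assay.

Compound 4 is therefore expected to give about 10 mg/kg, within a range from 4 mg/kg to 30 mg/kg, which means an estimated step of a 3.2-fold lower number from compound 3 to compound 4 (0.50 log units; beyond the scatter).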

Compound 4, dose for half-maximal effect: > 50 mg/kg
Compound 4 gave a limit, no number; the forecaster's own chance of this, stated with the estimate: 10%; at least 5.0-fold (0.69 log units) between middle value and limit.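

The value of compound 4 is a limit, not a number: the limit of > 50 mg/kg in this assay, at which 2 of the 4 values shown sit. Taking one methyl off the far nitrogen of the sulfamoyl group, while the nitrogen on the aromatic ring keeps its hydrogen, gives an at least 6.0-fold higher number from compound 1 to compound 4 (0.77 log units; beyond the scatter) in this assay, so a hydrogen on the ring nitrogen does not by itself bring a low number, and the far end of this group also counts, which the earlier compounds could not show. The comparison with the starting point gives only a bound, an at least 1.5-fold higher number from compound 3 to compound 4 (0.19 log units; that floor lies within the scatter), so it cannot say how much the combined change moved the read-out, only that the expected gain did not appear.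

On these data alone, it remains open how the read-out would respond to other groups on the far nitrogen, such as a diethylamino group, a longer chain or a plain amino group. As far as these compounds go, it is also open how far compound 4 lies beyond its limit, so the true size of the loss from removing that methyl stays unknown.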